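The source may report more compounds than this note shows. Statements on the series, on what has been measured and on what is new or still open speak of the compounds shown alone.

Measured compounds:
- compound 1, `Cc1ccc(C(=O)N/N=C/c2ccccc2)c(O)c1`: 53900 nM
- compound 2, `Cc1ccc(C(=O)N/N=C/c2cccc(F)c2)c(O)c1`: 31200 nM

In a functional assay (Mus musculus, strain BALB/C) for inhibition, read by MTT assay, with stated times of 24 h and 72 h (on this read-out lower numbers stand for stronger inhibition and higher numbers for weaker inhibition), compound 1 gives the highest of the two numbers shown; its nearest neighbour is compound 2, and the step of a 1.7-fold lower number from compound 1 to compound 2 (0.24 log units; within the scatter). Compound 3, `Cc1ccc(C(=O)N/N=C/c2ccc(F)cc2)c(O)c1`, differs from compound 1 by fluoro in place of hydrogen on an aromatic carbon. Going by the values given here, the only measured step that bears on this change is the one from compound 1 to compound 2, where the same fluoro for hydrogen exchange on another aromatic carbon gave a 1.7-fold lower number from compound 1 to compound 2 (0.24 log units; within the scatter), a move that stayed within the scatter. Among the compounds with values here, with a single step of that size as the sole guide, compound 3 is expected to land in this assay close to compound 1, with at most a modest lowering of the number, so the estimated step is a 1.7-fold lower number from compound 1 to compound 3 (0.23 log units; within the scatter). Compound 3 is therefore estimated at 32000 nM, within a range of 14000 nM to 75000 nM.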

Compound 3, half-maximal inhibitory concentration: 26700 nM
For compound 3 the middle estimate is 1.2-fold (0.08 log units) above the measured one, within the range that was stated.
By their numbers in this assay, from the lowest: compounds 3, 2 and 1 (each within the scatter of the next, the first and the last beyond it).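

Placed para to a large group, fluoro in place of hydrogen gives the first step in this assay that lies beyond the scatter: a 2.0-fold lower number from compound 1 to compound 3 (0.31 log units; beyond the scatter). The change remains modest, and the two fluoro compounds cannot be told apart, as compound 2 gives 31200 nM and compound 3 gives 26700 nM, values within the scatter of each other. No measurement at hand accounts for the step from hydrogen to fluoro at this place.

The compounds shown leave open whether a chloro, a methoxy or an amine at this same place would lower the number further than fluoro does, or whether a carboxylic acid would raise it. They also leave open whether the step from compound 1 would hold with a second fluoro on the same ring.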